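This account rests on a few compounds, and the source may have more. Where it says the series, first, only, none or still open, it means among the compounds named here.

Compound 1 `CC(CN)C(CN)C(=O)O` is the only one of the three with a number rather than a limit in an assay for inhibition of Ornithine decarboxylase (Rattus norvegicus) (a lower number here means a stronger inhibitor, a higher number a weaker inhibitor), where compound 1 gives 720000 nM. Compound 2 `CC(C)(CN)C(CN)C(=O)O` reaches only a limit of the assay, > 11000000 nM. Compound 3 `CC(C)(CN)CCN` likewise stops at a limit, > 10000000 nM. Compound 4 `CC(CN)C(C)CN` differs from compound 1 by methyl in place of carboxy on a saturated chain carbon bound to two saturated chain carbons. Going by the values given here, no measured step matches this change directly: the step of an at least 15-fold higher number from compound 1 to compound 2 (1.18 log units; beyond the scatter) concerns a methyl entering elsewhere, and the step that the two limits leave unreadable from compound 2 to compound 3 removes the same carboxy yet stays unreadable between two limits. With the carboxy gone, compound 4 is expected to give a weaker number, a step of a 4.2-fold higher number from compound 1 to compound 4 (0.62 log units; beyond the scatter). Compound 4 is therefore estimated at 3000000 nM, within 500000 nM to 15000000 nM.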

Compound 4, inhibition constant: 6100000 nM
For compound 4 the middle estimate is 2.0-fold (0.31 log units) below the measured one; measured number inside the range.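

Methyl in place of carboxy on this saturated chain carbon gives an 8.5-fold higher number from compound 1 to compound 4 (0.93 log units; beyond the scatter), the first readable size for the loss of the carboxy at this position. The same loss of carboxy could not be read from compound 2 to compound 3, because both compounds stop at limits, compound 3 at this one: the limit of > 10000000 nM in this assay, at which 1 of the 4 values shown sits. The compounds shown leave open what a hydroxymethyl, an amide or a methyl ester would give on this carbon in the core of compound 1. They also leave open what a plain hydrogen would give there.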